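A hydroxyethyl group in place of a chlorophenyl ring

A few compounds are considered here, and "the series" means these few. Any claim that something is new, unique, unknown or untested is made for them only; others in the source may bear on it.

Compound 1 `COc1ccc([C@@H]2CC(=O)c3c(O)cc(OCc4cn(Cc5cccc(Cl)c5)nn4)cc3O2)cc1O` gives 18200 nM in a functional assay on RAW264.7 cells (Mus musculus) for inhibition, read by Griess assay, with stated times of 2 h and 24 h; a lower number here means a stronger inhibitor, a higher number a weaker inhibitor.
Compound 2 `COc1ccc([C@@H]2CC(=O)c3c(O)cc(OCc4cn(Cc5ccccc5C(F)(F)F)nn4)cc3O2)cc1O` gives 12500 nM in this assay.
Compound 3 `C=CCn1cc(COc2cc(O)c3c(c2)O[C@H](c2ccc(OC)c(O)c2)CC3=O)nn1` gives 13800 nM in this assay.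

Compound 1 shows the highest of the three numbers, but the gaps a 1.3-fold lower number from compound 1 to compound 3 (0.12 log units; within the scatter) and a 1.5-fold lower number from compound 1 to compound 2 (0.16 log units; within the scatter) both lie within the scatter, so the three compounds cannot be told apart. Compound 4 `COc1ccc([C@@H]2CC(=O)c3c(O)cc(OCc4cn(CCCO)nn4)cc3O2)cc1O` differs from compound 1 in one place: 2-hydroxyethyl in place of 3-chlorophenyl on a saturated chain carbon bound to an aromatic nitrogen. All three measured steps concern this same position, a 1.5-fold lower number from compound 1 to compound 2 (0.16 log units; within the scatter), a 1.3-fold lower number from compound 1 to compound 3 (0.12 log units; within the scatter) and a 1.1-fold higher number from compound 2 to compound 3 (0.04 log units; within the scatter), and none of them reached beyond the scatter; among these compounds, exchanging the group here has changed little. In this assay the step is therefore expected to be small, a 1.2-fold lower number from compound 1 to compound 4 (0.08 log units; within the scatter). Compound 4 is estimated at 15000 nM, with a range from 7000 nM to 35000 nM.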

Compound 4, half-maximal inhibitory concentration: 16700 nM
The estimate for compound 4 lay 1.1-fold (0.05 log units) below the measured number; low and high end bracket the measured number.
By their numbers in this assay, from the lowest: compounds 2, 3, 4 and 1 (each within the scatter of the next).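

Among the compounds shown, only compound 4 carries a hydrogen-bond donor on this group, and it has no ring there. Even so, in this assay all three new steps stay within the scatter (a 1.1-fold lower number from compound 1 to compound 4 (0.04 log units; within the scatter)) and (a 1.2-fold higher number from compound 3 to compound 4 (0.08 log units; within the scatter)) and (a 1.3-fold higher number from compound 2 to compound 4 (0.13 log units; within the scatter)). So neither a benzene ring nor the lack of a hydroxyl is needed here to hold the number at this level. No measurement shown explains this result.

Going by these compounds, whether an amine or a carboxylic acid at the end of this chain would give a step beyond the scatter remains open. So does whether a longer chain would.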